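A few compounds are considered here, and "the series" means these few. Any claim that something is new, unique, unknown or untested is made for them only; others in the source may bear on it.

Measured in an ADME assay on L132 cells (Homo sapiens) for cytotoxicity, read by MTT assay, with a stated time of 72 h; on this read-out higher numbers stand for weaker inhibition and lower numbers for stronger inhibition:
Compound 1 `C=CCOc1cc(C2=C(c3cc(OC)c(OC)c(OC)c3)C(=O)C(O)C2)ccc1OC`: > 100 ug/mL
Compound 2 `COc1cc(C2=C(c3cc(C)c(OC)c(C)c3)C(OC(C)=O)CC2=O)cc(OC)c1OC`: > 100 ug/mL
Compound 3 `COc1ccc(C2=C(c3cc(OC)c(OC)c(OC)c3)C(=O)CC2O[SiH2]C(C)(C)C)cc1OC`: > 100 ug/mL

All three readings are limits of the assay and not numbers, and together they make up (the limit of > 100 ug/mL in this assay, at which 3 of the 3 values shown sit). Compound 1 therefore stands only at a limit, > 100 ug/mL, and compound 2 and compound 3 give it no numerical reference.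

Compound 4 `COc1ccc(C2=C(c3cc(OC)c(OC)c(OC)c3)C(=O)C(O)C2)cc1F` has not yet been measured. It differs from compound 1 by fluoro in place of allyloxy on an aromatic carbon, ortho to a methoxy group: fluoro in place of allyloxy on an aromatic carbon.

Going by the values given here, no step between measured compounds is available to size this change. In this assay, no shift beyond the usual scatter is therefore expected, though the evidence for this is thin. The expected change is a number no higher from compound 1 to compound 4 (the limit leaves the size open), and this is only an estimate. Compound 4 is expected to give 100 ug/mL. Its estimated range runs from 45 ug/mL to 220 ug/mL, and a report of a limit alone is the likelier outcome.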

Compound 4, half-maximal inhibitory concentration: < 1 ug/mL
Compound 4: a limit, no number; the forecaster's own chance of this, stated with the estimate: 75%; at least 100-fold (2.00 log units) between middle value and limit.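

In this assay, the aromatic carbon ortho to a methoxy group proves decisive on this core: fluoro in place of allyloxy gives an at least 100-fold lower number from compound 1 to compound 4 (2.00 log units; beyond the scatter). The earlier compounds shown here all sat at one limit and so showed no difference of any kind, whereas this single pair shows that a change at this one place can carry a compound clear across the range of the assay. The reading of compound 4, < 1 ug/mL, is itself a limit and not a number.

Going by these compounds, the pair cannot separate what fluoro adds from what the loss of allyloxy removes, and how far the step truly reaches also stays unknown. On these data alone, whether a chloro group, an amine or a shorter chain at this place would behave like fluoro or like allyloxy remains open.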